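The compounds below may be only part of what the source reports. "The series", "measured", "known", "first", "only" and "open" are said of these compounds alone.

Compound 1, with the structure `CC(/C=N/Nc1ccc([N+](=O)[O-])cc1)=N\NC(=O)c1ccccc1Nc1ccccc1`, shares its core with compound 2, whose structure is `CC(/C=N/Nc1ccc([N+](=O)[O-])cc1)=N\NC(=O)c1ccc(C(C)(C)C)cc1`, the two differing in the group attached to the carbonyl of the hydrazide. In a functional assay on cells (Splenocyte, Mus musculus, strain BALB/c) for inhibition, read by scintillation counting and thymidine incorporation, with a stated time of 72 h (on this read-out higher numbers stand for weaker inhibition and lower numbers for stronger inhibition), compound 1 gives "not determined" (no result reported), so no number stands for it. In this assay compound 2 gives > 12000 nM, a limit of the assay rather than a measured number. Among the measured compounds shown here, of the two values shown for this pair, one sits at the limit of > 12000 nM in this assay, at which 1 of the 2 values shown sits, so compound 1 has nothing to compare against, and no step between measured compounds can be drawn.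

Compound 3, with the structure `CC(/C=N/Nc1ccc([N+](=O)[O-])cc1)=N\NC(=O)c1ccccc1N`, is the next compound to be tested in this assay. It differs from compound 1 in one place: hydrogen in place of phenyl on a nitrogen on an aromatic ring. Since compound 1 has no number, no measured step sets a scale, and the only neighbouring result is the limit shown for compound 2, so no change beyond the scatter is expected from this exchange of a phenyl for a hydrogen. Compound 3 is therefore estimated to give 15000 nM in this assay, within a range from 4000 nM to 60000 nM.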

Compound 3, half-maximal inhibitory concentration: 4900 nM
For compound 3 the middle estimate is 3.1-fold (0.49 log units) above the measured one; the range from low to high includes it.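

Among the compounds shown here, compound 1 carries no number in this assay, so no step to compound 3 can be read from this result. Compound 2 stands at a limit of the assay rather than a number: the limit of > 12000 nM in this assay, at which 1 of the 3 values shown sits.

The compounds shown leave open how far the change from anilino to amino shifts inhibition in this assay.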